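This account rests on a few compounds, and the source may have more. Where it says the series, first, only, none or still open, it means among the compounds named here.

Compound 1 `CN1CCN(S(=O)(=O)c2ccc(-c3ccc4c(Nc5ccc(OCc6cccc(F)c6)c(Cl)c5)nccc4c3)cc2)CC1`: > 15 uM
Compound 2 `CN1CCN(S(=O)(=O)c2ccc(C3=CC4C(Nc5ccc(OCc6cccc(F)c6)c(Cl)c5)=NC=NC4S3)cc2)CC1`: > 15 uM

Both compounds were tested in a toxicity assay on HepG2 cells (Homo sapiens) for cytotoxicity, read by MTT assay, with a stated time of 48 h; on this read-out lower numbers stand for higher toxicity in this test and higher numbers for lower toxicity in this test. Compound 1 gives > 15 uM, which is a limit of the assay and not a number. Compound 2 gives > 15 uM, which is likewise a limit. The position of compound 1 is therefore shared, and the whole record so far reads: the limit of > 15 uM in this assay, at which 2 of the 2 values shown sit. Within the data shown here, no exact toxic concentration is known for either compound, and no measured pair differs in only one place.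

Compound 3 `CN1CCCN(S(=O)(=O)c2ccc(-c3ccc4c(Nc5ccc(OCc6cccc(F)c6)c(Cl)c5)nccc4c3)cc2)CC1` keeps the core of compound 1 but carries 4-methyl-1,4-diazepan-1-yl in place of 4-methylpiperazin-1-yl on a sulfonyl sulfur. The six-membered non-aromatic ring thus becomes a seven-membered one, while the counted hydrogen-bond donors and acceptors and the net charge stay the same.

Among the measured compounds shown here, with no measured step to serve as a guide, the expectation starts from compound 1 at > 15 uM. The expected step of a number no higher from compound 1 to compound 3 (the limit leaves the size open) is no larger than the scatter, with no favoured direction. For compound 3 the estimated value is 15 uM, with an expected range of 8 uM to 30 uM.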

Compound 3, half-maximal toxic concentration: > 15 uM
Compound 3 ended at the assay's limit; the forecaster's own chance of this, stated with the estimate: 75%; the middle value sits exactly at the limit.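

In this assay compound 3 gives > 15 uM, which is a limit and not a number. Among these compounds, compound 1 also rests on a limit, so no step from it to compound 3 can be read: the limit of > 15 uM in this assay, at which 3 of the 3 values shown sit. The compounds shown leave open how toxic each one is and whether the larger ring changes that at all.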